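Chloro to methyl on the aryl ring

The source may hold more compounds than are shown below. What is called first, only, known or untested is meant among the compounds shown, and "the series" means these compounds.

Measured so far in a functional assay on the whole organism with Mus musculus as the target (a lower number here means that less compound is needed, a higher number that more compound is needed for the effect), as follows
- compound 1 `Cc1ccc(-c2nc3cccnc3n2CC(=O)N(C)C)cc1` gives 4.7 mg/kg in this test
- compound 2 `CN(C)C(=O)Cn1c(-c2ccc(Cl)cc2)nc2ccc(Cl)nc21` gives 1.1 mg/kg in this test

Compound 2 holds the lower of the two numbers, and the gap to compound 1 lies beyond the scatter. Among the compounds with values here, only two values exist so far, so no trend can be drawn from them.

The next compound to read is compound 3 `Cc1ccc(-c2nc3ccc(Cl)nc3n2CC(=O)N(C)C)cc1`, which differs from compound 2 in one place. It has methyl in place of chloro on an aromatic carbon, para to a large group, turning 4-chlorophenyl into 4-methylphenyl (methyl in place of chloro on an aromatic carbon).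

Within the data shown here, no measured step isolates this change, so the expectation for this assay is only loosely anchored. The two measured values serve as the working bounds for the middle of the estimate. A move toward a higher number is expected, near the edge of the scatter, as a 2.1-fold higher number from compound 2 to compound 3 (0.32 log units; beyond the scatter) in this estimate. Compound 3 is estimated at 2.3 mg/kg within an expected range of 0.9 mg/kg to 5.5 mg/kg as the dose for half-maximal effect.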

Compound 3, dose for half-maximal effect: 2.7 mg/kg
Estimate against measurement, compound 3: 1.2-fold (0.07 log units) below; the measured number falls inside the stated range.
By their numbers in this assay, from the lowest: compound 2; then compounds 3 and 1 (each within the scatter of the next).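

At the aryl position, the change from 4-chlorophenyl to 4-methylphenyl in this assay gives a 2.5-fold higher number from compound 2 to compound 3 (0.39 log units; beyond the scatter), a modest step beyond the scatter and the first one-place reading of this position; among the compounds shown, the chloro form has the lower number. A second one-place reading, with 4-methylphenyl held constant, is a 1.7-fold lower number from compound 1 to compound 3 (0.24 log units; within the scatter), and this step stays within the scatter, so chloro in place of hydrogen on the core does not separate compound 1 and compound 3. No supporting measurement bears on why the aryl change shifts the dose.

The compounds shown leave open whether the gap between chloro and methyl on the aryl ring would persist with hydrogen in place of the chloro on the core, and how a methoxy group, a fluoro group or an amine would read at the same aryl position. They also leave open how far these readings carry over when the dimethyl amide shared by all three compounds gives way to a carboxylic acid or a longer chain.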